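The source may report more compounds than this note shows. Statements on the series, on what has been measured and on what is new or still open speak of the compounds shown alone.

Measured in a physicochemical assay for solubility, in phosphate buffer, at pH 7.2; a higher number here means a more soluble compound, a lower number a less soluble compound:
compound 1 `COc1cc(C2CN(C(=O)c3cc(OCCO)ccn3)C2)ccc1OCc1ccc(C2CC2)cc1`: 800 nM
compound 2 `COc1cc(C2CN(C(=O)c3cc(OC[C@@H](O)CO)ccn3)C2)ccc1OCc1ccc(C2CC2)cc1`: 3100 nM
compound 3 `COc1cc(C2CN(C(=O)c3cc(COCC(CO)(CO)CO)ccn3)C2)ccc1OCc1ccc(C2CC2)cc1`: 1500 nM

Compound 3 does not hold the top number of this short set. Two steps fix its place: a 2.1-fold lower number from compound 2 to compound 3 (0.32 log units; beyond the scatter), and a 1.9-fold higher number from compound 1 to compound 3 (0.27 log units; within the scatter).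

Compound 4 `COc1cc(C2CN(C(=O)c3cc(COCC(CO)CO)ccn3)C2)ccc1OCc1ccc(C2CC2)cc1` follows from compound 3 by hydrogen in place of hydroxymethyl on a saturated chain carbon bound to three saturated chain carbons.

The closest measured edit is the reverse kind, a hydroxymethyl added on a saturated chain carbon, seen in a 3.9-fold higher number from compound 1 to compound 2 (0.59 log units; beyond the scatter). Taken alone, that step points to a lower number for compound 4, but it was measured on a different chain. The step of a 2.1-fold lower number from compound 2 to compound 3 (0.32 log units; beyond the scatter) gives no support for that direction, since it reaches the larger branched group with a lower number. The evidence is thin and mixed, so no step beyond the scatter is expected. The estimated change is a 1.2-fold lower number from compound 3 to compound 4 (0.06 log units; within the scatter).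

For compound 4 the expected value is 1300 nM, with an estimated range of 550 nM to 3200 nM.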

Compound 4, solubility: 4700 nM
Beside the measured number, compound 4's estimate is 3.6-fold (0.56 log units) below it, and the stated range ends below it.
By their numbers in this assay, from the lowest: compounds 1 and 3 (each within the scatter of the next); then compounds 2 and 4 (each within the scatter of the next).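

Working notes: in this assay, hydrogen in place of hydroxymethyl on a saturated chain carbon bound to three saturated chain carbons does not lower the number (a 3.1-fold higher number from compound 3 to compound 4 (0.50 log units; beyond the scatter)), which runs opposite to the hydroxymethyl addition on the other chain (a 3.9-fold higher number from compound 1 to compound 2 (0.59 log units; beyond the scatter)), so more hydroxymethyl does not track with a higher number across these compounds, and compound 3 goes against any such pattern. The (3-hydroxy-2-(hydroxymethyl)propoxy)methyl group stands within the scatter of 2,3-dihydroxypropoxy (a 1.5-fold higher number from compound 2 to compound 4 (0.18 log units; within the scatter)) and well clear of 2-hydroxyethoxy (a 5.9-fold higher number from compound 1 to compound 4 (0.77 log units; beyond the scatter)). Nothing available accounts for these steps.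

Open, going by these compounds, is whether the step at this carbon holds with another group there, such as an amine or a carboxylic acid. Also open, on these data alone, is how a longer chain carrying the same hydroxymethyl groups would read.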